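The source may report more compounds than this note shows. Statements on the series, on what has been measured and on what is new or still open speak of the compounds shown alone.

Measured compounds:
compound 1 `CCCCN(c1nc2ccccc2o1)[C@H](C)c1ccc(-c2ccccc2-c2nnn[nH]2)cc1` — 3.2 h
compound 2 `Cc1ccc(-c2nc(=O)o[nH]2)c(-c2ccc([C@@H](C)N(CC3CC3)c3nc4c(C(=O)O)cccc4o3)cc2)c1` — 2.8 h
compound 3 `CCCCN(c1nc2c(C(=O)O)cccc2o1)[C@H](C)c1ccc(-c2cc(Cl)ccc2-c2nc(=O)o[nH]2)cc1` — 2 h

All three were measured in an ADME assay on the whole organism (Macaca fascicularis) for metabolic stability, read by LC-MS, using cassette dosing, at a dose of 1 mg/kg by the oral route; on this read-out higher numbers stand for a longer-lived compound and lower numbers for a shorter-lived compound. Compound 1 gives 3.2 h, the top figure among the three, yet compound 2 with 2.8 h and compound 3 with 2 h both fall within the usual scatter of that figure, so the three compounds cannot be told apart on this read-out. Compound 4 `CCCCN(c1nc2c(-c3nccn3C)cccc2o1)[C@H](C)c1ccc(-c2ccccc2-c2nnn[nH]2)cc1` has not yet been measured in this assay. It comes from compound 1 by one change: 1-methyl-1H-imidazol-2-yl in place of hydrogen on an aromatic carbon. Among the measured compounds shown here, no measured pair in this set shows the effect of such a change, so the direction of the step cannot be drawn from the data. Since every measured compound here, whatever sits on that ring, lands in the same narrow band, the expected step of a 1.2-fold lower number from compound 1 to compound 4 (0.09 log units; within the scatter) is none beyond the scatter. Compound 4 is therefore estimated at 2.6 h, with a plausible range from 1.2 h to 5.5 h.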

Compound 4, half-life: 3.9 h
Beside the measured number, compound 4's estimate is 1.5-fold (0.18 log units) below it; the measured number falls inside the stated range.
By their numbers in this assay, from the lowest: compounds 3, 2, 1 and 4 (each within the scatter of the next).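

In this assay, among the compounds shown here, the step of a 1.2-fold higher number from compound 1 to compound 4 (0.09 log units; within the scatter) is the first in this set that isolates a single change at one place, here 1-methyl-1H-imidazol-2-yl in place of hydrogen on an aromatic carbon, ortho to a fused ring and meta to a fused ring. This position therefore accepts a whole five-membered aromatic ring, with its methyl group, and the read-out shows no difference beyond the scatter. No supporting measurement bears on this result, so it can be reported only as an observation.

As far as these compounds go, it remains open how an amine or a methoxy group at the same aromatic carbon would behave. From the compounds shown here alone, it is also open whether 1-methyl-1H-imidazol-2-yl would give a similar step on a compound whose other parts differ from those of compound 1.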